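The compounds below may be only part of what the source reports. "The series", "measured", "known", "first", "only" and "open" are said of these compounds alone.

Measured in a functional assay on HCT-15 cells (Homo sapiens) for antiproliferative activity, read by MTT assay, with a stated time of 72 h; on this read-out lower numbers stand for stronger inhibition and higher numbers for weaker inhibition:
- Compound 1 `CCCCn1ccnc1-c1cc(OC)c(OC)c(OC)c1`: > 100000 nM (a limit, not a number)
- Compound 2 `COc1cc(-c2nccn2-c2ccc3sccc3c2)cc(OC)c1OC`: 3300 nM

Compound 1 stands at the limit of > 100000 nM in this assay, at which 1 of the 2 values shown sits. Its true value is therefore not known, and any comparison with it has an open end. Compound 2 does give a number, 3300 nM, and it carries an aromatic ring group on the aromatic nitrogen where compound 1 has its butyl.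

Compound 3 `COc1cc(-c2nccn2-c2ccc(Br)cc2)cc(OC)c1OC` makes a similar kind of change to compound 1, with 4-bromophenyl in place of butyl on an aromatic nitrogen. Within the data shown here, no measured pair of compounds differs in one place only, so the size of this step can only be judged loosely. The best guide is compound 2 at 3300 nM. The expected change is an at least 25-fold lower number from compound 1 to compound 3 (1.39 log units; beyond the scatter), in the direction of stronger inhibition in this assay. For compound 3 the estimated value is 4000 nM, within an expected range of 700 nM to 25000 nM.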

Compound 3, half-maximal inhibitory concentration: 11700 nM
For compound 3 the middle estimate is 2.9-fold (0.47 log units) below the measured one; the measured number falls inside the stated range.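

In this assay, this position on an aromatic nitrogen now has a change in one place that can be sized: 4-bromophenyl in place of butyl gives an at least 8.5-fold lower number from compound 1 to compound 3 (0.93 log units; beyond the scatter). So a single six-membered aromatic ring of carbon, carrying bromine, is enough to bring a measurable number, and the ring group of compound 2 is not the only group at this position to do so. Compound 1 stands at a limit, not a number, so this step has an open end and its true size may be larger: the limit of > 100000 nM in this assay, at which 1 of the 3 values shown sits.

The compounds shown do not tell whether the step belongs to the aromatic ring itself or to the bromine on it, and a plain phenyl group would be needed to separate the two. Going by these compounds, how a benzyl group or a longer chain would read at this position also stays open.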